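The source may hold more compounds than are shown below. What is called first, only, known or untested is meant among the compounds shown, and "the series" means these compounds.

Working notes on the series. Among the compounds with values here, compound 1 `Nc1sc2c(c1-c1nc3cc(Cl)ccc3s1)CCC2` and compound 2 `Oc1ccccc1/C=N/c1sc2c(c1-c1nc3ccccc3s1)CCC2` are the two measured members; compound 3 `Oc1ccccc1/C=N/c1sc2c(c1-c1nc3cc(Cl)ccc3s1)CCC2` has not yet been tested. In an ADME assay on HepG2 cells (Homo sapiens) for cytotoxicity, read by MTT assay, with a stated time of 72 h (a lower number here means that less compound is tolerated, a higher number that more compound is tolerated), compound 1 gives 67.8 ug/mL, and in this assay compound 2 gives 156 ug/mL, the higher of the two numbers, a difference that lies beyond the usual scatter. Within the data shown here, compound 1 and compound 2 differ in more than one place, so no single step can be drawn between them. Compound 3 is reached from compound 2 by one change: chloro in place of hydrogen on an aromatic carbon. Among the measured compounds shown here, no measured pair isolates this change, so the direction is open; a modest shift is expected, if any, and it is estimated that the step from compound 2 to compound 3 amounts to a 1.4-fold lower number from compound 2 to compound 3 (0.15 log units; within the scatter). For compound 3 in this assay the value is estimated at 110 ug/mL, expected to lie between 50 ug/mL and 230 ug/mL.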

Compound 3, half-maximal cytotoxic concentration: 210 ug/mL
Compound 3: middle estimate off by 1.9-fold (0.28 log units), on the low side, within the range that was stated.
By their numbers in this assay, from the lowest: compound 1; then compounds 2 and 3 (each within the scatter of the next).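

In this assay, chloro in place of hydrogen on an aromatic carbon gives a 1.3-fold higher number from compound 2 to compound 3 (0.13 log units; within the scatter), so this first readable pair for the change shows no separation at this position of the six-membered aromatic ring. With chloro held constant, the group of 9 heavy atoms in place of one nitrogen atom gives a 3.1-fold higher number from compound 1 to compound 3 (0.49 log units; beyond the scatter), which places a difference beyond the scatter on a single exchange at that aromatic carbon. No available evidence bears on the size of either step.

On these data alone, the chloro step is read only with the group of 9 heavy atoms present, so whether it would hold alongside the unchanged nitrogen of compound 1 remains open. As far as these compounds go, what a methoxy group or a carboxylic acid would do in place of chloro at this position also remains open.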